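The source may hold more compounds than are shown below. What is called first, only, known or untested is meant among the compounds shown, and "the series" means these compounds.

Two compounds share one core, a chlorinated bicyclic system carrying a hydrazone linker. Compound 1 `Cc1ccc(/C=N\NC(=O)C2=C(Cl)c3ccccc3CCC2)cc1` places the carbonyl on that core and a methylphenyl group on the far side of the linker. Compound 2 `O=C(N/N=C/C1=C(Cl)c2ccccc2CCC1)c1ccccc1` has the arrangement turned around, with a plain benzoyl group on the hydrazide side and the core on the aldehyde side. In a functional assay on MDA-MB-231 cells (Homo sapiens) for inhibition, read by sulforhodamine B assay, with a stated time of 48 h (a lower number here means a stronger inhibitor of growth, a higher number a weaker inhibitor of growth), compound 1 gives 260 nM. In this assay compound 2 gives 11100 nM, the higher of the two numbers, so compound 2 is the weaker growth inhibitor of the pair, and the gap lies well beyond the usual scatter.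

Compound 3 `Nc1ccccc1C(=O)N/N=C/C1=C(Cl)c2ccccc2CCC1` keeps the arrangement of compound 2 and differs from it in one place: amino in place of hydrogen on an aromatic carbon. Going by the values given here, no measured pair shows this particular change, so its effect in this assay is not known from the data. The expectation is a small shift toward a lower number, of a size near the edge of the scatter rather than clearly beyond it. Compound 3 is expected to give 5000 nM, with a likely range from 1500 nM to 25000 nM. That estimate implies an expected step of a 2.2-fold lower number from compound 2 to compound 3 (0.35 log units; beyond the scatter).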

Compound 3, concentration for 50% growth inhibition: 5000 nM
Compound 3: the middle estimate sits on the measured number at the digits printed, within the range that was stated.
By their numbers in this assay, from the lowest: compound 1; then compound 3; then compound 2.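

Going by these compounds alone, compound 2 and compound 3 are the first pair here that differ in one place only, so the effect of a single change can be read directly rather than inferred from compounds that differ in several ways. In this assay amino in place of hydrogen, on an aromatic carbon ortho to a large group, gives a 2.2-fold lower number from compound 2 to compound 3 (0.35 log units; beyond the scatter) and so shows that this carbon can carry a small substituent without any loss of growth inhibition, though the gain is modest. No measurement of any property of the amino group is available to account for this step.

Still open, on these data alone, is whether a different group on this same carbon, such as hydroxyl, methoxy or dimethylamino, would give a larger or smaller step, and whether amino on another carbon of the ring would act as it does here. Also open, as far as these compounds go, is whether the same change would give a similar step in the turned-around arrangement of compound 1, which differs from compound 3 in more than one place and so cannot be compared with it directly.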